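This account rests on a few compounds, and the source may have more. Where it says the series, first, only, none or still open, it means among the compounds named here.

- Compound 1 `Nc1nc(NCCNc2ncc(-c3ncc[nH]3)c(-c3ccccc3Cl)n2)ccc1[N+](=O)[O-]`: > 0.5 h
- Compound 2 `Nc1nc(NCCNc2ncc(-c3ncc[nH]3)c(-c3cc(F)ccc3F)n2)ccc1[N+](=O)[O-]`: > 0.5 h

In an ADME assay on microsomes from liver (Canis lupus familiaris) for metabolic stability (a lower number here means that the compound disappears faster, a higher number that the compound lasts longer), compound 1 gives > 0.5 h, which is a limit of the assay and not a number. Compound 2 gives > 0.5 h, again only a limit. Compound 2 therefore stands at the limit of > 0.5 h in this assay, at which 2 of the 2 values shown sit. Compound 3 `Nc1nc(NCCNc2ncc(-c3ncc[nH]3)c(-c3ccc(F)cc3C(F)(F)F)n2)ccc1[N+](=O)[O-]` changes the same aromatic substituent: 4-fluoro-2-(trifluoromethyl)phenyl in place of 2,5-difluorophenyl on an aromatic carbon. For the measured compounds named here, the one measured step at this place is a step that the two limits leave unreadable from compound 1 to compound 2, so it gives no size to build on. No step beyond the usual scatter is therefore expected in this assay, and the estimate is a step that the limit leaves unreadable from compound 2 to compound 3. The half-life expected for compound 3 is 0.9 h, within an estimated range of 0.4 h to 2.5 h.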

Compound 3, half-life: > 0.5 h
Compound 3 was reported as a limit; the forecaster's own chance of this, stated with the estimate: 85%; the middle value does not contradict the limit.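

No step can be read among compound 1, compound 2 and compound 3, as each value is a limit of the assay and not a number: the limit of > 0.5 h in this assay, at which 3 of the 3 values shown sit. The compounds shown leave open the actual half-life of each and whether these aromatic substituents differ in this assay.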